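Working notes: heteroaryl swap on the shared core

The compounds below may be only part of what the source reports. "The series", "measured", "known", "first", "only" and "open" are said of these compounds alone.

Compound 3 `NS(=O)(=O)c1ccc(-c2cnc(C(=O)CCCCCCc3ccccc3)o2)s1` gives 3 nM in an assay (Rattus norvegicus) for inhibition of Fatty-acid amide hydrolase 1 (Homo sapiens) (a higher number here means a weaker inhibitor, a lower number a stronger inhibitor), the lowest number of the three measured; compound 2 `N#Cc1ccccc1-c1cnc(C(=O)CCCCCCc2ccccc2)o1` gives 130 nM and compound 1 `Nc1ccccc1-c1cnc(C(=O)CCCCCCc2ccccc2)o1` gives 750 nM. Both steps toward compound 3 were large, a 250-fold lower number from compound 1 to compound 3 (2.40 log units; beyond the scatter) and a 43-fold lower number from compound 2 to compound 3 (1.64 log units; beyond the scatter), while the step of a 5.8-fold lower number from compound 1 to compound 2 (0.76 log units; beyond the scatter) was modest. Compound 4 `O=C(CCCCCCc1ccccc1)c1ncc(-c2ccncn2)o1` differs from compound 3 by pyrimidin-4-yl in place of 5-sulfamoylthiophen-2-yl on an aromatic carbon. Going by the values given here, no measured step tests the pyrimidin-4-yl group itself; the only guide is that compound 1 and compound 2, which lack the 5-sulfamoylthiophen-2-yl group, sit far higher in this assay. For compound 4 a large step toward a higher number is therefore expected, a 50-fold higher number from compound 3 to compound 4 (1.70 log units; beyond the scatter). Compound 4 is estimated at 150 nM, with a range of 30 nM to 700 nM.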

Compound 4, inhibition constant: 2.3 nM
Estimate against measurement, compound 4: 65-fold (1.81 log units) above, outside the stated range (below it).
By their numbers in this assay, from the lowest: compounds 4 and 3 (each within the scatter of the next); then compound 2; then compound 1.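

In this assay, the 5-sulfamoylthiophen-2-yl group proves unnecessary for a low number at this position: pyrimidin-4-yl, a smaller six-membered ring, holds that level (a 1.3-fold lower number from compound 3 to compound 4 (0.12 log units; within the scatter)). The same group also separates clearly from the substituted phenyl rings (a 57-fold lower number from compound 2 to compound 4 (1.75 log units; beyond the scatter); a 330-fold lower number from compound 1 to compound 4 (2.51 log units; beyond the scatter)), so a low number here is not confined to one ring type. No measurement on hand accounts for these results.

Open, from the compounds shown here alone, is whether a plain phenyl or unsubstituted thiophene ring would reach this level. Also open, going by these compounds, is how an amine or a carboxylic acid on the pyrimidine ring would change the number.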